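A phenol returns to the hydrazone terminus

The source may report more compounds than this note shows. Statements on the series, on what has been measured and on what is new or still open speak of the compounds shown alone.

Measured compounds:
compound 1, `C/C(=N\NC(=O)c1cccc(S(=O)(=O)N2CCOCC2)c1)c1cc(F)ccc1O`, 1150 nM
compound 2, `O=C(N/N=C/c1ccccn1)c1cccc(S(=O)(=O)N2CCOCC2)c1`, > 100000 nM

In a functional assay on SMMC-7721 cells (Homo sapiens) for antiproliferative activity, read by MTT assay, with a stated time of 72 h (on this read-out lower numbers stand for stronger inhibition and higher numbers for weaker inhibition), compound 2 reaches only a limit, > 100000 nM, namely (the limit of > 100000 nM in this assay, at which 1 of the 2 values shown sits). Compound 1 gives 1150 nM in this assay. Compound 3 is `COc1ccc(/C=N/NC(=O)c2cccc(S(=O)(=O)N3CCOCC3)c2)c(O)c1`; it differs from compound 2 in one place: 2-hydroxy-4-methoxyphenyl in place of pyridin-2-yl on a carbon with a double bond to nitrogen. Going by the values given here, no measured step shows this change. Among the compounds with values here, the account expects for compound 3 a gain beyond the scatter in this assay, an at least 33-fold lower number from compound 2 to compound 3 (1.52 log units; beyond the scatter), since compound 1, the only numbered value here, gives 1150 nM. Compound 3 is therefore estimated at 3000 nM, within a range from 800 nM to 30000 nM.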

Compound 3, half-maximal inhibitory concentration: 3950 nM
Beside the measured number, compound 3's estimate is 1.3-fold (0.12 log units) below it, and the stated range covers the measured number.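

In this assay, 2-hydroxy-4-methoxyphenyl in place of pyridin-2-yl on a carbon with a double bond to nitrogen gives an at least 25-fold lower number from compound 2 to compound 3 (1.40 log units; beyond the scatter), so this position can carry a large gain. The entering group brings a hydrogen-bond donor that the leaving group lacks, but this single step cannot tie the gain to it. The step's full size stays unknown, as compound 2 reaches only a limit: the limit of > 100000 nM in this assay, at which 1 of the 3 values shown sits.

The compounds shown leave open whether the hydroxy or the methoxy group accounts for the gain. They also leave open how an amine or a carboxylic acid on the same ring would fare.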